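The source may report more compounds than this note shows. Statements on the series, on what has been measured and on what is new or still open speak of the compounds shown alone.

Compound 3 `COc1ccccc1S(=O)(=O)Nc1ccc2oc(-c3ccccc3)nc2c1` carries a 2-methoxyphenyl on the sulfonyl sulfur. In an ADME assay on HEK293 cells (Homo sapiens) for cytotoxicity, read by resazurin assay, with a stated time of 48 h (on this read-out lower numbers stand for higher toxicity in this test and higher numbers for lower toxicity in this test), compound 3 gives 41000 nM. Compound 1 `Cc1cccc(S(=O)(=O)Nc2ccc3oc(-c4ccccc4)nc3c2)c1` gives 69000 nM, and compound 3 sits within the usual scatter of that number. Compound 2 `O=S(=O)(Nc1ccc2oc(-c3ccccc3)nc2c1)c1ccc(O)cc1` reaches only the assay limit of > 100000 nM. The measured steps, a 1.7-fold lower number from compound 1 to compound 3 (0.23 log units; within the scatter) and an at least 2.4-fold lower number from compound 2 to compound 3 (0.38 log units; beyond the scatter), both exchange the whole ring on the sulfonyl sulfur. Compound 4 `COc1ccc(Cl)cc1S(=O)(=O)Nc1ccc2oc(-c3ccccc3)nc2c1` differs from compound 3 by chloro in place of hydrogen on an aromatic carbon. For the measured compounds named here, none of the measured steps involves a chloro entering a ring, so they offer little guidance; the step from compound 3 to compound 4 is expected to stay within the scatter, a 1.2-fold lower number from compound 3 to compound 4 (0.07 log units; within the scatter), in no firm direction. Compound 4 is estimated at 35000 nM, with a range from 15000 nM to 90000 nM.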

Compound 4, half-maximal cytotoxic concentration: 74000 nM
Compound 4: middle estimate off by 2.1-fold (0.33 log units), on the low side; low and high end bracket the measured number.
By their numbers in this assay, from the lowest: compounds 3, 1 and 4 (each within the scatter of the next). At a limit, above all of these: compound 2.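

Unlike the earlier steps, which exchange the whole ring on the sulfonyl sulfur, this one only adds a chloro para to the methoxy group, and in this assay it gives a 1.8-fold higher number from compound 3 to compound 4 (0.26 log units; within the scatter). The 5-chloro-2-methoxyphenyl ring also stays close to the 3-methylphenyl ring, with a 1.1-fold higher number from compound 1 to compound 4 (0.03 log units; within the scatter). Compound 2 is held at a limit, so an at least 1.3-fold lower number from compound 2 to compound 4 (0.13 log units; that floor lies within the scatter) is only a floor: the limit of > 100000 nM in this assay, at which 1 of the 4 values shown sits.

Going by these compounds, it remains open whether a bromo, an amine or a carboxylic acid at this place would move the number beyond the scatter. On these data alone, it is also open whether chloro would behave the same way on a ring without the methoxy group.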